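This account rests on a few compounds, and the source may have more. Where it says the series, first, only, none or still open, it means among the compounds named here.

Measured in a functional assay on A2780 cells (Homo sapiens) for inhibition, read by sulforhodamine B assay, with a stated time of 72 h; a higher number here means a weaker inhibitor, a lower number a stronger inhibitor:
- compound 1 `O=C(NCc1ccc(S(=O)(=O)N2CCCCC2)cc1)c1cnc2nccn2c1`: 130 nM
- compound 2 `O=C(NCc1ccc(S(=O)(=O)N2CCCCC2)cc1)c1ccc2nc[nH]c2c1`: > 10000 nM (a limit of the assay)
- compound 3 `O=C(NCc1ccc(S(=O)(=O)N2CCCCC2)cc1)c1cc2cccnc2s1`: > 10000 nM (a limit of the assay)

Compound 1 is the only one of these with a true number. Compounds 2 and 3 stand at the limit of > 10000 nM in this assay, at which 2 of the 3 values shown sit.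

Compound 4 `O=C(NCc1ccc(S(=O)(=O)c2cccc(C(F)(F)F)c2)cc1)c1cnc2nccn2c1` keeps the group that compound 1 carries on its carbonyl carbon and changes another: 3-(trifluoromethyl)phenyl in place of piperidin-1-yl on a sulfonyl sulfur.

The measured steps, an at least 76-fold higher number from compound 1 to compound 2 (1.88 log units; beyond the scatter) and an at least 76-fold higher number from compound 1 to compound 3 (1.88 log units; beyond the scatter), are large, but both change the group on the carbonyl carbon, so they bear only indirectly. Compound 4 keeps the group that those steps lost. Going by the values given here, no measured step touches the sulfonyl sulfur, so the direction is a judgement, and a moderate move to a lower number is expected. The estimated change is a 3.7-fold lower number from compound 1 to compound 4 (0.57 log units; beyond the scatter). For compound 4 the expected value is 35 nM, with an estimated range of 6 nM to 250 nM.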

Compound 4, half-maximal inhibitory concentration: 2 nM
Beside the measured number, compound 4's estimate is 18-fold (1.24 log units) above it, and the stated range ends above it.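

In this assay, the sulfonyl sulfur turns out to be a second place where one change matters greatly: 3-(trifluoromethyl)phenyl in place of piperidin-1-yl gives a 65-fold lower number from compound 1 to compound 4 (1.81 log units; beyond the scatter). The earlier steps shown here changed only the group on the carbonyl carbon and ended at limits of the assay, whereas this step keeps that group and reaches a lower number.

As far as these compounds go, whether a plain phenyl, or a morpholine in place of the piperidine, would do the same stays open. Nothing shown accounts for the size of this step.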